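This account rests on a few compounds, and the source may have more. Where it says the series, first, only, none or still open, it means among the compounds named here.

In a functional assay on SNB-75 cells (Homo sapiens) for inhibition, read by sulforhodamine B assay, with a stated time of 48 h (a higher number here means a weaker inhibitor of growth, a lower number a stronger inhibitor of growth), compound 1 `CN1CCN(CCCOc2cccc3nc(Nc4ccc(Cl)c(F)c4)ccc23)CC1` gives "not determined" (no result reported) and so has no place on the scale. The same is true of compound 3 `CN1CCN(CCCOc2cccc3nc(Nc4cc(Cl)cc(Cl)c4)ccc23)CC1` with "not determined" (no result reported) as its entry. Only compound 2 `CC(C)c1ccc(Nc2ccc3c(OCCCN4CCN(C)CC4)cccc3n2)cc1` provides a number in this assay with 12800 nM as its result, so there is no measured value for compound 1 to start from.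

The unmeasured compound 4 `CN1CCN(CCCOc2cccc3nc(Nc4cccc(Cl)c4)ccc23)CC1` keeps the core of compound 1 and carries 3-chlorophenyl in place of 4-chloro-3-fluorophenyl on a nitrogen on an aromatic ring. Within the data shown here, no measured pair shows what a swap of this kind does. The expectation is therefore a step no larger than the usual scatter in this assay and in neither direction. Among the measured compounds shown here, with compound 1 unmeasured, the best anchor is compound 2 at 12800 nM as the only number available, although it is a loose guide. Compound 4 is expected to give about 10000 nM in this assay with 3000 nM to 30000 nM as the estimated range.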

Compound 4, concentration for 50% growth inhibition: 1380 nM
The estimate for compound 4 lay 7.2-fold (0.86 log units) above the measured number; measured number below the stated range.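

In this assay, the group on the nitrogen on an aromatic ring proves able to move the result: 3-chlorophenyl in place of 4-isopropylphenyl, with the rest of the molecule unchanged, gives a 9.3-fold lower number from compound 2 to compound 4 (0.97 log units; beyond the scatter). Among these compounds, this is the first measured step at this position, and it shows that growth inhibition in these cells responds to which substituted phenyl the nitrogen carries. The data in hand offer no explanation for the size of this step.

The steps from compound 1 and compound 3 to compound 4 cannot be read, with no number for either of those two compounds. On these data alone, whether a plain phenyl group or a pyridine ring on that nitrogen would give a lower or a higher number than compound 4 also stays open.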